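Moving the chlorine on the phenyl ring: compound 4

The source may report more compounds than this note shows. Statements on the series, on what has been measured and on what is new or still open speak of the compounds shown alone.

Measured so far:
compound 1 `CC(C)(CCCCOc1cc(-c2ccccc2)c2ccccc2n1)C(=O)O` gives 183 nM
compound 2 `CC(C)(CCCCOc1cc(-c2ccc(Cl)cc2)c2ccccc2n1)C(=O)O` gives 15 nM
compound 3 `CC(C)(CCCCOc1cc(-c2ccc(N)cc2)c2ccccc2n1)C(=O)O` gives 40 nM

All three values come from an assay on membranes from spleen (Cavia porcellus) for binding affinity to leukotriene B4 receptor 1 (Homo sapiens); a lower number here means a stronger inhibitor, a higher number a weaker inhibitor. Compound 3 stands second highest of the three numbers: compound 2 gives a lower number, with a 2.7-fold higher number from compound 2 to compound 3 (0.43 log units; beyond the scatter), while compound 1 gives a higher one, with a 4.6-fold lower number from compound 1 to compound 3 (0.66 log units; beyond the scatter).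

Compound 4 `CC(C)(CCCCOc1cc(-c2cccc(Cl)c2)c2ccccc2n1)C(=O)O` differs from compound 3 in one place: 3-chlorophenyl in place of 4-aminophenyl on an aromatic carbon. Among the measured compounds shown here, no measured compound carries a 3-chlorophenyl, so no step covers this change directly. For the measured compounds named here, two steps bear on it indirectly. Chloro in place of hydrogen on the phenyl ring gave a 12-fold lower number from compound 1 to compound 2 (1.09 log units; beyond the scatter), and amino in place of chloro gave a 2.7-fold higher number from compound 2 to compound 3 (0.43 log units; beyond the scatter). Both point the same way: a chlorine on that ring goes with a lower number than hydrogen or amino. Compound 2 carries its chlorine elsewhere on the ring, so the gain may not carry over in full.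

The expectation for compound 4 in this assay is therefore a number between those of compound 1 and compound 2, estimated at 30 nM, within 10 nM to 100 nM. This estimated step, a 1.3-fold lower number from compound 3 to compound 4 (0.12 log units; within the scatter), is expected to stay within the scatter.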

Compound 4, half-maximal inhibitory concentration: 1100 nM
Beside the measured number, compound 4's estimate is 37-fold (1.56 log units) below it; the whole stated range lies below it.
By their numbers in this assay, from the lowest: compound 2; then compound 3; then compound 1; then compound 4.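

In this assay the place of the chlorine on the phenyl ring matters as much as its presence: 4-chlorophenyl lowered the number relative to plain phenyl, whereas 3-chlorophenyl goes the other way, giving a 6.0-fold higher number from compound 1 to compound 4 (0.78 log units; beyond the scatter) for the same change of hydrogen to chloro. Moving the chlorine alone produces a 73-fold higher number from compound 2 to compound 4 (1.87 log units; beyond the scatter) and is the largest step among these compounds, which leaves compound 4 as the weakest of the four. Even the 4-aminophenyl, which carries no chlorine, does far better, as a 28-fold higher number from compound 3 to compound 4 (1.44 log units; beyond the scatter) shows, so a chlorine on this ring does not by itself bring a lower number.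

Nothing given here supplies a reason for the gap between the two chlorine placements. Still open, as far as these compounds go, is whether other groups respond to placement as sharply as chlorine does, for instance a 3-aminophenyl set against the 4-aminophenyl, or a fluorine or a methoxy group at either of these two places, and how a 2-chlorophenyl would compare with both chlorine compounds.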